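The compounds below may be only part of what the source reports. "The series", "measured", "known", "first", "only" and "open" are said of these compounds alone.

Measured compounds:
- compound 1, `Oc1ccc(-c2cc(-c3cccc(Cl)c3)nc(-c3ccccn3)c2)cc1`: 59.4%
- compound 2, `Oc1ccc(-c2cc(-c3cccc(Cl)c3)nc(-c3cccs3)c2)cc1`: 52.4%
- compound 3, `Oc1cccc(-c2cc(-c3cccs3)nc(-c3ccccc3Cl)c2)c1`: 2.7%

All three were tested in an assay on isolated protein for inhibition of DNA topoisomerase 1 (Homo sapiens), with a stated time of 30 min, tested at 100 uM; a higher number here means a stronger effect of the compound at the concentration tested, a lower number a weaker effect. Compound 1 reaches 59.4% and compound 2 reaches 52.4%, while compound 3 gives only 2.7%, the lowest of the three numbers, and its distance to both others lies beyond the scatter. Compound 2 and compound 3 are built from the same atoms joined differently; the difference between the two cores is not broken down here.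

Compound 1 and compound 2 differ in one place: pyridin-2-yl in place of thiophen-2-yl on an aromatic carbon. The step that goes with it is a number 7 percentage points higher from compound 2 to compound 1 (within the scatter), so this change on its own left the read-out essentially where it was.

The unmeasured compound 4, `Oc1cccc(-c2cc(-c3ccccn3)nc(-c3ccccc3Cl)c2)c1`, is made from compound 3 by the same kind of change: pyridin-2-yl in place of thiophen-2-yl on an aromatic carbon. The surroundings are not identical, though: in the earlier pair the place is meta to a 3-chlorophenyl group and meta to a 4-hydroxyphenyl group, whereas here it is meta to a 2-chlorophenyl group and meta to a 3-hydroxyphenyl group. Because the earlier step of a number 7 percentage points higher from compound 2 to compound 1 (within the scatter) stayed within the scatter, the expected step of a number 5.3 percentage points higher from compound 3 to compound 4 (within the scatter) in this assay is likewise expected to be small. Compound 4 is therefore estimated to give about 8%, most likely between 0% and 25%.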

Compound 4, a percentage reported as inhibition, at one concentration (the size of the read-out at that concentration, not a potency): 0%
Estimate against measurement, compound 4: 8 percentage points above, within the range that was stated.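

In this assay, putting pyridin-2-yl in place of thiophen-2-yl on the core of compound 3 gave a number 2.7 percentage points lower from compound 3 to compound 4 (within the scatter), and setting this beside the earlier pair shows no difference between the two cores: the same change on two cores in this assay, a number 7 percentage points higher (within the scatter) from compound 2 to compound 1 and a number 2.7 percentage points lower (within the scatter) from compound 3 to compound 4, 9.7 percentage points apart, within the scatter of two such steps

So in these two pairs, the change left the read-out essentially where it was, and that result held on both cores. Going by these compounds alone, this does not show that the change is neutral in general, since only two cores are involved and compound 3 gives 2.7% while compound 4 gives 0%, numbers so close to the bottom of the scale that this pair had little room to show any further loss.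

The two cores differ in more than one place, so the compounds shown leave open which of those differences separates the high numbers of compound 1 and compound 2 from the low numbers of compound 3 and compound 4. Also open, on these data alone, is how a different group in that same place, such as a furan ring, a carboxylic acid or a simple amine, would behave on either core.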